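Adding one amino group to the only measured nucleoside

The compounds below may be only part of what the source reports. "The series", "measured", "known", "first", "only" and "open" are said of these compounds alone.

Within the data shown here, in a functional assay on HeLa S3 cells (Homo sapiens) for antiproliferative activity, read by XTT assay, with a stated time of 72 h (on this read-out lower numbers stand for stronger inhibition and higher numbers for weaker inhibition), compound 2 `C#Cc1cn([C@@H]2O[C@H](CO)[C@@H](O)[C@H]2O)c2ncnc(OC)c12` gives 1730 nM, the only true number in this small set. Compound 1 `COc1ncnc2c1c(-c1ccccc1)cn2[C@@H]1O[C@H](CO)[C@@H](O)[C@H]1O` reports only a limit of the assay, > 20000 nM. Compound 3 `C#Cc1cn([C@@H]2O[C@H](CO)[C@@H](O)[C@H]2O)c2ncnc(NC)c12` also reports only a limit, > 20000 nM. Compound 4 `C#Cc1cn([C@@H]2O[C@H](CO)[C@@H](O)[C@H]2O)c2nc(N)nc(OC)c12` is still unmeasured and carries one change from compound 2: amino in place of hydrogen on an aromatic carbon, between two ring nitrogen atoms.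

Two measured steps offer indirect guidance. The first, an at least 11-fold lower number from compound 1 to compound 2 (1.06 log units; beyond the scatter), and the second, an at least 11-fold higher number from compound 2 to compound 3 (1.06 log units; beyond the scatter), are both large, so one small change can shift this assay strongly in this set. Neither step touches the new site. The second is the closer guide, since it also brings in a nitrogen-bearing group on an aromatic carbon, and it weakened inhibition. A moderate move towards weaker inhibition is therefore expected, a 2.9-fold higher number from compound 2 to compound 4 (0.46 log units; beyond the scatter). Compound 4 is estimated at 5000 nM, within an expected range of 800 nM to 20000 nM.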

Compound 4, half-maximal inhibitory concentration: > 20000 nM
Compound 4: a limit, no number; the forecaster's own chance of this, stated with the estimate: 30%; at least 4.0-fold (0.60 log units) between middle value and limit.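

In this assay, among these compounds, this is the first change at the carbon between two ring nitrogen atoms, and putting amino in place of hydrogen there gives an at least 11-fold higher number from compound 2 to compound 4 (1.06 log units; beyond the scatter). Compound 2 therefore loses its measurable inhibition through a change at this site as well as through the earlier change of methoxy to methylamino, so the site is sensitive to at least this one group. From the compounds shown here alone, the printed step is only a lower bound, and its full size stays unknown because compound 4 gives a limit and not a number: the limit of > 20000 nM in this assay, at which 3 of the 4 values shown sit.

The compounds shown leave open whether a methyl group or a chlorine atom at this carbon would keep the inhibition of compound 2. They also leave open whether any group here can give a lower number than compound 2.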